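Removing the benzyl fluorine from a cytotoxicity-tolerant scaffold

This account rests on a few compounds, and the source may have more. Where it says the series, first, only, none or still open, it means among the compounds named here.

Compound 1 `O=c1c(C2=CS(=O)(=O)c3cc(F)ccc3N2)c(O)c2cc(F)ccc2n1Cc1ccc(F)cc1`, compound 2 `CS(=O)(=O)Nc1ccc2c(c1)S(=O)(=O)C=C(c1c(O)c3cc(F)ccc3n(Cc3ccc(F)cc3)c1=O)N2` and compound 3 `CS(=O)(=O)Nc1ccc2c(c1)S(=O)(=O)C=C(c1c(O)c3cc(Cl)ccc3n(Cc3ccc(F)cc3)c1=O)N2` share one core and were all tested in an ADME assay on 2209-23 cells (Homo sapiens) for cytotoxicity, read by WST assay; a higher number here means that more compound is tolerated, a lower number that less compound is tolerated. Compound 1 reached only a limit there, > 50000 nM. Compound 2 likewise gave a limit, > 50000 nM, so it stands among values of which none is a number. Compound 3 also returned a limit, > 50000 nM. The steps a step that the two limits leave unreadable from compound 1 to compound 2 and a step that the two limits leave unreadable from compound 2 to compound 3 therefore have no readable size, since (the limit of > 50000 nM in this assay, at which 3 of the 3 values shown sit). Compound 4 `CS(=O)(=O)Nc1ccc2c(c1)S(=O)(=O)C=C(c1c(O)c3cc(F)ccc3n(Cc3ccccc3)c1=O)N2` differs from compound 2 by hydrogen in place of fluoro on an aromatic carbon. Among the measured compounds shown here, no measured step has a readable size, so he expects no shift beyond the scatter, a step that the limit leaves unreadable from compound 2 to compound 4. For compound 4 he estimates 80000 nM, between 30000 nM and 200000 nM.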

Compound 4, half-maximal cytotoxic concentration: > 50000 nM
Compound 4 gave a limit, no number (the forecaster's own chance of this, stated with the estimate: 85%); the middle value is on the limit's open side.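

No size can be read for the step between compound 2 and compound 4 in this assay, since both gave only a limit: the limit of > 50000 nM in this assay, at which 4 of the 4 values shown sit.

The compounds shown leave open whether 4-fluorobenzyl to benzyl shifts cytotoxicity at all, and at what concentration any of them would become cytotoxic.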